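Series notes: methoxy in place of fluoro at the aryl ring

This account rests on a few compounds, and the source may have more. Where it says the series, first, only, none or still open, it means among the compounds named here.

Of the compounds shown here, three on a shared core have been measured. In an assay on isolated protein for binding affinity to 5-hydroxytryptamine receptor 1D (Homo sapiens) (on this read-out lower numbers stand for stronger inhibition and higher numbers for weaker inhibition), compound 1 `Cc1cccc(-c2n[nH]cc2N2CCCNCC2)c1` gives 3290 nM, compound 2 `Clc1ccc(-c2n[nH]cc2N2CCCNCC2)cc1` gives 1230 nM, and compound 3 `Fc1cccc(-c2n[nH]cc2N2CCCNCC2)c1` gives 2540 nM. Compound 3 stands second highest of the three in this assay: its nearest neighbour is compound 1, a step within the scatter, and its furthest is compound 2, a gap beyond the scatter. For the measured compounds named here, the only measured step touching the site of interest is a 1.3-fold lower number from compound 1 to compound 3 (0.11 log units; within the scatter), and it stays within the scatter.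

Compound 4 `COc1cccc(-c2n[nH]cc2N2CCCNCC2)c1` is not yet measured. It differs from compound 3 by methoxy in place of fluoro on an aromatic carbon, the change sitting on an aromatic carbon of a six-membered aromatic ring of carbon only, meta to a large group. Going by the values given here, no measured pair shows methoxy against fluoro, so the one swap at this position, from compound 1 to compound 3 with a 1.3-fold lower number from compound 1 to compound 3 (0.11 log units; within the scatter), is the only guide, and it gives no step beyond the scatter. On that basis compound 4 is expected near 2500 nM, within 1000 nM to 6500 nM. The expected step is a 1.0-fold lower number from compound 3 to compound 4 (0.01 log units; within the scatter).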

Compound 4, inhibition constant: > 10000 nM
Compound 4: no number, only a limit; the forecaster's own chance of this, stated with the estimate: 5%; middle value at least 4.0-fold (0.60 log units) away from the limit.
By their numbers in this assay, from the lowest: compound 2; then compounds 3 and 1 (each within the scatter of the next). At a limit, above all of these: compound 4.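

This position is not indifferent to what it carries. Fluoro in place of methyl gave only a 1.3-fold lower number from compound 1 to compound 3 (0.11 log units; within the scatter), whereas methoxy on the same aromatic carbon gives an at least 3.9-fold higher number from compound 3 to compound 4 (0.59 log units; beyond the scatter) and an at least 3.0-fold higher number from compound 1 to compound 4 (0.48 log units; beyond the scatter). In this assay, for the compounds shown here, the reading for compound 4 is a limit and not a number: the limit of > 10000 nM in this assay, at which 1 of the 4 values shown sits. Both steps therefore give only a minimum size, and they are the first sign that this carbon, meta to a large group, separates one substituent from another.

Compared with fluoro, methoxy brings 2 heavy atoms and 1 hydrogen-bond acceptor, and the compounds shown do not tell whether the oxygen or the added carbon goes with the higher number. A hydroxyl, an ethyl or an amine on the same carbon would bear on that question.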